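Carboxy for Benzyloxy at the Amine Side Chain

A few compounds are considered here, and "the series" means these few. Any claim that something is new, unique, unknown or untested is made for them only; others in the source may bear on it.

Measured so far:
Compound 1, `CCNC(=O)NC1=CS(=O)(=O)O[C@@]12[C@@H](CO[Si](C)(C)C(C)(C)C)O[C@@H](n1cc(C)c(=O)n(C)c1=O)[C@@H]2O[Si](C)(C)C(C)(C)C`: 4260 nM
Compound 2, `Cc1cn([C@@H]2O[C@H](CO[Si](C)(C)C(C)(C)C)[C@@]3(OS(=O)(=O)C=C3NCC(=O)OCc3ccccc3)[C@H]2O[Si](C)(C)C(C)(C)C)c(=O)n(C)c1=O`: 250000 nM

For the measured compounds named here, in a functional assay on CCRF-CEM cells (Homo sapiens) (a lower number here means that less compound is tolerated, a higher number that more compound is tolerated), compound 2 gives 250000 nM and stands at the highest of the two numbers, with compound 1 at 4260 nM as its only neighbour. Going by the values given here, the one measured step, a 59-fold higher number from compound 1 to compound 2 (1.77 log units; beyond the scatter), concerns a different exchange on the amine nitrogen and therefore speaks to the sensitivity of this part of the molecule rather than to the change now in question.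

Compound 3, `Cc1cn([C@@H]2O[C@H](CO[Si](C)(C)C(C)(C)C)[C@@]3(OS(=O)(=O)C=C3NCC(=O)C(=O)O)[C@H]2O[Si](C)(C)C(C)(C)C)c(=O)n(C)c1=O`, keeps the shared core of compound 2 and differs from it only in the side chain: carboxy in place of benzyloxy on a carbonyl carbon. No measured pair covers a carboxy in place of a benzyloxy on a carbonyl carbon, so the direction of this step cannot be read from the data; only its neighbourhood, where a single change already moved the number far, gives reason to allow a wide range.

Compound 3 is therefore expected to stay close to compound 2, with the step of a 1.3-fold lower number from compound 2 to compound 3 (0.10 log units; within the scatter), and is estimated at 200000 nM with a range from 30000 nM to 1000000 nM.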

Compound 3, half-maximal cytotoxic concentration: 72600 nM
The estimate for compound 3 lay 2.8-fold (0.44 log units) above the measured number; the range from low to high includes it.
By their numbers in this assay, from the lowest: compound 1; then compound 3; then compound 2.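

In this assay, carboxy in place of benzyloxy on a carbonyl carbon gives a real but modest change (a 3.4-fold lower number from compound 2 to compound 3 (0.54 log units; beyond the scatter)), smaller than the earlier exchange on the amine nitrogen. The number therefore responds not only to which group replaces ethylcarbamoyl on the amine nitrogen, but also to what sits on the carbonyl carbon of the side chain, here with the six-membered aromatic ring gone and a hydrogen-bond donor added. The move closes only part of the gap to the ethylcarbamoyl compound, as a large step still remains (a 17-fold higher number from compound 1 to compound 3 (1.23 log units; beyond the scatter)), so both side chains on this nitrogen stand well above the ethylcarbamoyl compound.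

The compounds shown leave open whether a small methyl ester or a primary amide on the same carbonyl carbon would fall nearer to compound 2 or to compound 3, and so whether the aromatic ring or the free carboxy group matters more to the shift. No accompanying measurement bears on why the number moved in either step.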